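This account rests on a few compounds, and the source may have more. Where it says the series, first, only, none or still open, it means among the compounds named here.

Measured in a functional assay on HT-29 cells (Homo sapiens) for antiproliferative activity, read by MTT assay, with a stated time of 24 h; on this read-out lower numbers stand for stronger inhibition and higher numbers for weaker inhibition:
- compound 1 `COc1ccc(/C=C/C(=O)c2ccc(OC)c3c2OC(C)(C)C=C3)cn1`: > 10000 nM (a limit)
- compound 2 `COc1ccc(C(=O)/C=C/c2ccccn2)c2c1C=CC(C)(C)O2`: 2120 nM

The reading for compound 1 is a limit of the assay and not a number: > 10000 nM.

For the measured compounds named here, that leaves compound 2 with the only true number so far in this assay, 2120 nM.

Compound 3 `COc1ccc(C(=O)/C=C/c2ccc(O)cc2)c2c1C=CC(C)(C)O2` keeps the shared core and carries 4-hydroxyphenyl in place of pyridin-2-yl on a double-bonded chain carbon bound to a double-bonded chain carbon.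

Going by the values given here, only one measured step bears on this change, an at least 4.7-fold lower number from compound 1 to compound 2 (0.67 log units; beyond the scatter), which lies beyond the scatter and favoured pyridin-2-yl at this same place. Losing that group is therefore expected to move the number modestly upward, toward weaker inhibition, though 4-hydroxyphenyl itself is untested here.

The expected size of the change is a 2.1-fold higher number from compound 2 to compound 3 (0.33 log units; beyond the scatter).

The estimate for compound 3 is 4500 nM, with an expected range from 1300 nM to 15000 nM.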

Compound 3, half-maximal inhibitory concentration: > 10000 nM
Compound 3: a limit, no number (the forecaster's own chance of this, stated with the estimate: 25%); at least 2.2-fold (0.34 log units) between middle value and limit.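

In this assay, exchanging pyridin-2-yl for 4-hydroxyphenyl gives an at least 4.7-fold higher number from compound 2 to compound 3 (0.67 log units; beyond the scatter), so this position does not accept every six-membered aromatic ring equally. For the compounds shown here, compound 3 ends at a limit of the assay, so the true size of this loss remains unknown, and pyridin-2-yl is the only group here to give a true number. The step from compound 1 to compound 3 cannot be read, because both readings are limits: the limit of > 10000 nM in this assay, at which 2 of the 3 values shown sit.

Whether the ring nitrogen of pyridin-2-yl matters stays open, as plain phenyl, which would test this directly, is not among the compounds shown. It is also unknown whether pyridin-3-yl, or a phenyl ring carrying an amine or a carboxylic acid, would give a lower number than compound 2.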